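From butyl to 1-phenylethyl on the amide nitrogen

The source may report more compounds than this note shows. Statements on the series, on what has been measured and on what is new or still open speak of the compounds shown alone.

In a functional assay on MCF7 cells (Homo sapiens) for antiproliferative activity, read by MTT assay, with a stated time of 24 h (a lower number here means a stronger inhibitor, a higher number a weaker inhibitor), compound 1 (`CCCCc1oc2ccccc2c1C(=O)c1ccc(OCC(=O)NC(C)C)cc1`) gives > 50000 nM as a limit of the assay and not a number. Compound 2 (`CCCCNC(=O)CCCOc1ccc(C(=O)c2c(CCCC)oc3ccccc23)cc1`) gives > 50000 nM as a limit as well, so its place on the scale is known only as that limit. Within the data shown here, the one measured step is a step that the two limits leave unreadable from compound 1 to compound 2 and offers no size to carry forward. What the data show is the limit of > 50000 nM in this assay, at which 2 of the 2 values shown sit, and nothing finer. Compound 3 (`CCCCc1oc2ccccc2c1C(=O)c1ccc(OCCCC(=O)N[C@@H](C)c2ccccc2)cc1`) has 1-phenylethyl in place of butyl on an amide-type nitrogen and keeps the rest of compound 2 unchanged. No measured step sizes this change, so a further reading at the limit in this assay remains likely. The expected change is an at least 1.1-fold lower number from compound 2 to compound 3 (0.04 log units; that floor lies within the scatter) and any number that appears would mean a stronger inhibitor. Compound 3 is estimated at 45000 nM with an expected range from 15000 nM to 100000 nM in this measurement.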

Compound 3, half-maximal inhibitory concentration: > 50000 nM
Compound 3: a limit, no number; the forecaster's own chance of this, stated with the estimate: 60%; at least 1.1-fold (0.04 log units) between middle value and limit.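

Among these compounds, compound 3, like compound 2, gives only a limit of the assay and not a number in this assay, so no step from compound 2 to compound 3 can be read. The compounds shown leave open whether changing the group on the amide nitrogen alters activity at all, as every reading stops at the same point: the limit of > 50000 nM in this assay, at which 3 of the 3 values shown sit.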